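The compounds below may be only part of what the source reports. "The series", "measured", "known", "first", "only" and "open" are said of these compounds alone.

For the measured compounds named here, in a functional assay on HEK293 cells for agonist activity at Vasopressin V2 receptor (Homo sapiens), read by a luciferase reporter and cAMP accumulation (on this read-out lower numbers stand for an effect already at smaller amounts and higher numbers for an effect only at larger amounts of compound), compound 1 `Cc1cc(C(=O)N2CCCCc3ccccc32)ccc1CNC(=O)Nc1ccccc1F` gives 30 nM and compound 2 `Cc1cc(C(=O)N2CCCCc3ccccc32)ccc1CNC(=O)NCC(N)=O` gives 210 nM; compound 2 thus stands at the higher of the two numbers, the only measured step being a 7.0-fold higher number from compound 1 to compound 2 (0.85 log units; beyond the scatter). Compound 3 `Cc1cc(C(=O)N2CCCCc3ccccc32)ccc1CNC(=O)NCC(=O)N(C)C` differs from compound 2 by dimethylamino in place of amino on a carbonyl carbon. Going by the values given here, that single measured step concerns the group on the amide-type nitrogen, not the carbonyl carbon altered here, so no measured step bears directly on this change. A step within the usual scatter is therefore expected, a 1.2-fold higher number from compound 2 to compound 3 (0.08 log units; within the scatter). For compound 3 the value expected in this assay is 250 nM, within a range from 80 nM to 800 nM.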

Compound 3, half-maximal effective concentration: 58 nM
Compound 3: the middle estimate sits 4.3-fold (0.63 log units) above what was measured, outside the stated range (below it).
By their numbers in this assay, from the lowest: compounds 1 and 3 (each within the scatter of the next); then compound 2.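

In this assay dimethylamino in place of amino on the carbonyl carbon is a step beyond the scatter (a 3.6-fold lower number from compound 2 to compound 3 (0.56 log units; beyond the scatter)), so this position responds to the group it carries. With (dimethylcarbamoyl)methyl in place of 2-fluorophenyl on the amide-type nitrogen, the step stays within the scatter (a 1.9-fold higher number from compound 1 to compound 3 (0.29 log units; within the scatter)), so this read-out does not separate those two groups, unlike carbamoylmethyl. Nothing available explains the step from amino to dimethylamino.

Open: whether a methylamino group on the same carbonyl carbon would read like amino or like dimethylamino. Going by these compounds, a pyrrolidinyl or morpholinyl group there, or a longer chain before the carbonyl, is equally open.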